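The source may hold more compounds than are shown below. What is called first, only, known or untested is meant among the compounds shown, and "the series" means these compounds.

Compound 1 `CC(=O)C1=C[C@@H]2[C@H](C(C)C)CC[C@@H](C)[C@]2(O)C1`: > 10 ug/mL
Compound 2 `CC(=O)[C@H]1C[C@]2(O)[C@@H]([C@@H]1O)[C@H](C(C)C)CC[C@H]2C`: > 10 ug/mL

In a functional assay on BGC-823 cells (Homo sapiens) for cytotoxicity, read by MTT assay (a lower number here means a stronger inhibitor, a higher number a weaker inhibitor), compound 1 gives > 10 ug/mL, which is a limit of the assay rather than a number. In this assay compound 2 likewise gives > 10 ug/mL, again only a limit. For the measured compounds named here, both values therefore sit at the limit of > 10 ug/mL in this assay, at which 2 of the 2 values shown sit, so no step between measured compounds can be sized. Compound 3 `CC(=O)[C@@H]1C[C@]2(O)[C@@H]([C@H]1O)[C@H](C(C)C)CC[C@H]2C` has not yet been measured. Set against compound 2, (the two compounds have the same atoms and bonds and differ only in configuration as drawn: 2 of 6 stereo elements differ; a stereocentre at a saturated ring carbon is drawn S in compound 2 and R in compound 3; a stereocentre at a saturated ring carbon is drawn S in compound 2 and R in compound 3). With both measured compounds at the limit, the step that the limit leaves unreadable from compound 2 to compound 3 is expected to be none beyond the scatter. Compound 3 is expected to give about 15 ug/mL, within 5 ug/mL to 50 ug/mL.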

Compound 3, half-maximal inhibitory concentration: > 10 ug/mL
Compound 3: a limit, no number; the forecaster's own chance of this, stated with the estimate: 75%; the middle value lies beyond the limit too.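

No step can be read between compound 2 and compound 3, because both values are limits and not numbers: the limit of > 10 ug/mL in this assay, at which 3 of the 3 values shown sit. The compounds shown leave open whether their difference in configuration changes the result at all in this assay.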